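From Methoxy to Chloro in an Antiproliferative Pair

This account rests on a few compounds, and the source may have more. Where it says the series, first, only, none or still open, it means among the compounds named here.

Among the compounds with values here, in a functional assay on MCF7 cells (Homo sapiens) for antiproliferative activity, read by MTT assay, with a stated time of 72 h (a higher number here means a weaker inhibitor, a lower number a stronger inhibitor), compound 1 (`O=S1(=O)C=Cc2ccc(Nc3ccc(C(F)(F)F)cc3)cc21`) gives 1270 nM and compound 2 (`COc1ccc(Nc2ccc3c(c2)S(=O)(=O)C=C3)cc1`) gives 1210 nM, so compound 2 stands level with its only measured neighbour. Compound 3 (`O=S1(=O)C=Cc2ccc(Nc3ccc(Cl)cc3)cc21`) has chloro in place of methoxy on an aromatic carbon, para to a large group: chloro in place of methoxy on an aromatic carbon. Within the data shown here, the one measured step, methoxy in place of trifluoromethyl on an aromatic carbon, is a 1.0-fold lower number from compound 1 to compound 2 (0.02 log units; within the scatter). No change beyond the scatter is therefore expected in this assay. The expected step is a 1.0-fold lower number from compound 2 to compound 3 (0.00 log units; within the scatter). For compound 3 the estimate is 1200 nM, with an expected range of 550 nM to 2500 nM.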

Compound 3, half-maximal inhibitory concentration: 2670 nM
Estimate against measurement, compound 3: 2.2-fold (0.35 log units) below, and the stated range ends below it.
By their numbers in this assay, from the lowest: compounds 2 and 1 (each within the scatter of the next); then compound 3.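

In this assay this position turns out able to shift the number, which the level pair of earlier compounds did not show: chloro in place of methoxy gives a 2.2-fold higher number from compound 2 to compound 3 (0.34 log units; beyond the scatter), and chloro in place of trifluoromethyl gives a 2.1-fold higher number from compound 1 to compound 3 (0.32 log units; beyond the scatter). Both steps are modest, yet they leave compound 3 as the weakest of the three. Nothing available here explains this difference. As far as these compounds go, it remains open whether bromo would follow chloro at this position, and how an amine or a carboxylic acid there would read.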